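Compound 3: a limit with no measured step to hexyloxy

A few compounds are considered here, and "the series" means these few. Any claim that something is new, unique, unknown or untested is made for them only; others in the source may bear on it.

Compound 1 `Nc1nc(NC2CC2)c2ncn(/C=C3/CC3(CO)CO)c2n1`: 71500 nM
Compound 2 `Nc1nc(NC2CCCCC2)c2ncn(/C=C3/CC3(CO)CO)c2n1`: > 20000 nM
Compound 3 `CC(C)CNc1nc(N)nc2c1ncn2/C=C1/CC1(CO)CO`: > 20000 nM

These three compounds were tested in an ADME assay on BCBL1 cells (Homo sapiens) for cytotoxicity, with a stated time of 7 days; on this read-out higher numbers stand for lower toxicity in this test and lower numbers for higher toxicity in this test. Compound 3 gives > 20000 nM, which is a limit and not an exact number. Compound 2 also gives a limit, > 20000 nM. Together they make up (the limit of > 20000 nM in this assay, at which 2 of the 3 values shown sit). Among the measured compounds shown here, the only exact number belongs to compound 1, at 71500 nM.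

Compound 4 `CCCCCCOc1nc(N)nc2c1ncn2/C=C1/CC1(CO)CO` differs from compound 3 on an aromatic carbon of the shared core: hexyloxy in place of isobutylamino on an aromatic carbon. The closest evidence is a step that the limit leaves unreadable from compound 1 to compound 3 and a step that the two limits leave unreadable from compound 2 to compound 3. Both swap the group on the nitrogen, and neither has a readable size. For the measured compounds named here, no measured compound carries hexyloxy, so the size and direction of this step remain uncertain. The expected change is modest, a step that the limit leaves unreadable from compound 3 to compound 4, and it may not exceed the scatter. For compound 4 the estimate is 30000 nM, with an expected range from 8000 nM to 100000 nM.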

Compound 4, half-maximal cytotoxic concentration: > 20000 nM
Compound 4 gave a limit, no number; the forecaster's own chance of this, stated with the estimate: 55%; the middle value lies beyond the limit too.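

Among the compounds shown here, compound 4 also gives only a limit, so no step to it from compound 1, compound 2 or compound 3 can be read: the limit of > 20000 nM in this assay, at which 3 of the 4 values shown sit. The compounds shown leave open whether hexyloxy and the amino groups on the shared core differ at all in this assay.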